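The source may hold more compounds than are shown below. What is called first, only, known or untested is meant among the compounds shown, and "the series" means these compounds.

Working notes on the series. Compound 1 `N#CC1=C(N)N(c2ccc(S(N)(=O)=O)cc2)C2=C(C(=O)CCC2)C1c1ccc(O)cc1` gives in a functional assay on Ehrlich cells (Mus musculus) for antiproliferative activity, read by trypan blue exclusion, with a stated time of 2 h, tested at 100 ug/mL (on this read-out higher numbers stand for a stronger effect at the one concentration tested and lower numbers for a weaker effect), a value of 100%. Compound 2 `N#CC1=C(N)N(c2ccc(S(N)(=O)=O)cc2)C2=C(C(=O)CCC2)C1c1cccc([N+](=O)[O-])c1` gives in this assay a value of 71%, and compound 3 `N#CC1=C(N)N(c2ccc(S(N)(=O)=O)cc2)C2=C(C(=O)CCC2)C1c1ccc(Cl)cc1Cl` gives in this assay a value of 95%. Compound 3 thus holds the second highest of the three numbers; the step of a number 5 percentage points lower from compound 1 to compound 3 (within the scatter) means that these two cannot be told apart, while the step of a number 24 percentage points higher from compound 2 to compound 3 (beyond the scatter) separates compound 3 clearly from compound 2.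

Compound 4 `N#CC1=C(N)N(c2ccc(S(N)(=O)=O)cc2)C2=C(C(=O)CCC2)C1c1cccs1` carries the change (thiophen-2-yl in place of 2,4-dichlorophenyl on a saturated ring carbon). For the measured compounds named here, all three measured steps change the group on the same saturated ring carbon: a number 29 percentage points lower from compound 1 to compound 2 (beyond the scatter) is the only change that moved the number beyond the scatter, whereas a number 5 percentage points lower from compound 1 to compound 3 (within the scatter) did not. Going by the values given here, no measured step carries thiophen-2-yl, so the direction rests only on the observation that two of three aryl groups gave high numbers. Compound 4 is therefore expected to show a step of a number 7 percentage points lower from compound 3 to compound 4 (within the scatter) in this assay, not beyond the scatter. The estimate for compound 4 is 88%, with a range from 65% to 100%.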

Compound 4, a percentage reported as activity, at one concentration (the size of the read-out at that concentration, not a potency): 100%
Beside the measured number, compound 4's estimate is 12 percentage points below it; low and high end bracket the measured number.
By their numbers in this assay, from the lowest: compound 2; then compounds 3, 1 and 4 (each within the scatter of the next).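

With thiophen-2-yl on the saturated ring carbon, this assay gives a number 5 percentage points higher from compound 3 to compound 4 (within the scatter) and no change at the digits printed from compound 1 to compound 4 (within the scatter), so a five-membered aromatic ring with a sulfur atom stands level with the two six-membered aryl groups at the top of the series. Against the remaining aryl group the change gives a number 29 percentage points higher from compound 2 to compound 4 (beyond the scatter), which leaves compound 2 as the only compound of the four set apart from the others. The data offer no explanation for this separation.

Open, as far as these compounds go, is whether this position also tolerates a group with no aromatic ring, such as cyclohexyl or a longer alkyl chain, or a basic amine such as a piperidine. With a single concentration per compound, compounds 1, 3 and 4 remain unresolved in potency.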